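Shortening the Amide Chain and Adding a Hydroxy Group

The source may hold more compounds than are shown below. What is called first, only, known or untested is meant among the compounds shown, and "the series" means these compounds.

Of the compounds shown here, three sharing one core have been tested in a functional assay on the whole organism (strain Wistar) for inhibition, with Rattus norvegicus as the target, read by paw edema, with stated times of 60 min and 1 h, at a dose of 100 mg/kg by the oral route; on this read-out lower numbers stand for less inhibition and higher numbers for more inhibition at the one dose given (going by the name of the read-out). Compound 1 `COc1cc2c(cc1OC)C(CC(N)=O)CC2` gives 18.8%, compound 2 `CCN(CC)C(=O)CC1CCc2cc(OC)c(OC)cc21` gives 31.3%, and compound 3 `CCCCCCNC(=O)CC1CCc2cc(OC)c(OC)cc21` gives 47.6%. Compound 3 stands highest of the three, with compound 2 nearest and compound 1 furthest from it. The measured steps show that a number 28.8 percentage points higher from compound 1 to compound 3 (beyond the scatter) and that a number 16.3 percentage points higher from compound 2 to compound 3 (beyond the scatter); in both cases the hexyl chain on the amide-type nitrogen went with the higher number.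

Compound 4 `COc1cc2c(cc1OC)C(CC(=O)NCCO)CC2` keeps this core but differs from compound 3 as follows: hydroxy in place of butyl on a saturated chain carbon, two bonds along the chain from an amide-type nitrogen. Among the measured compounds shown here, the step from compound 1 to compound 3 bears on this change most directly, since compound 4 moves part of the way back toward compound 1 in chain length, while also bringing in a hydroxy group for which no measured step exists. Compound 4 is therefore expected to fall between compound 1 and compound 3 in this assay, a downward step a number 19.6 percentage points lower from compound 3 to compound 4 (beyond the scatter) beyond the scatter. The estimate for compound 4 is 28%, within a range from 15% to 42%.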

Compound 4, a percentage reported as inhibition, in the whole organism at one dose (the size of the read-out at that dose, not a potency): 0%
Compound 4: the middle estimate sits 28 percentage points above what was measured; the measured number lies below the stated range.
By their numbers in this assay, from the lowest: compound 4; then compound 1; then compound 2; then compound 3.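

In this assay, the 2-hydroxyethyl group on the amide-type nitrogen does not act like a shorter version of the hexyl chain: replacing hexylamino with (2-hydroxyethyl)amino gives a number 47.6 percentage points lower from compound 3 to compound 4 (beyond the scatter) and replacing diethylamino with it gives a number 31.3 percentage points lower from compound 2 to compound 4 (beyond the scatter) in the second comparison. Until now, each larger group on this nitrogen had gone with a higher number than the plain amide, but here 2-hydroxyethyl in place of hydrogen gives a number 18.8 percentage points lower from compound 1 to compound 4 (beyond the scatter) and so reverses that direction. No measurement shown here explains this reversal.

Compound 4 brings in a shorter chain and a hydroxy group in a single change, so these compounds cannot separate the two. A plain ethyl, a 2-methoxyethyl or a 6-hydroxyhexyl group on the same nitrogen would help to tell them apart.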